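Notes on compound 4 as a shortened form of compound 2

The source may report more compounds than this note shows. Statements on the series, on what has been measured and on what is new or still open speak of the compounds shown alone.

Measured so far:
compound 1 `CCC(C)C(NC(=O)NO)C(=O)NC1CCCCC1` gives 150000 nM
compound 2 `CCC(C)C1NC(=O)N(C2CCCC2)C1=O` is reported only as a limit, > 200000 nM
compound 3 `CCC(C)C(NC(=O)NO)C(=O)NCc1ccccc1` gives 126000 nM

In a functional assay on MOLT-4 cells (Homo sapiens) for inhibition (on this read-out higher numbers stand for weaker inhibition and lower numbers for stronger inhibition), compound 1 gives 150000 nM and compound 3 gives 126000 nM. For compound 2 the read-out is a limit of the assay and not a number, > 200000 nM. Compound 2 thus stands at the limit of > 200000 nM in this assay, at which 1 of the 3 values shown sits.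

Compound 4 `CC(C)C1NC(=O)N(C2CCCC2)C1=O` differs from compound 2 by hydrogen in place of methyl on a saturated chain carbon, two bonds along the chain from a saturated ring carbon. No measured pair among these compounds shows this change. The expected step that the limit leaves unreadable from compound 2 to compound 4 is none beyond the scatter. Compound 4 is therefore estimated at 300000 nM, range 100000 nM to 1000000 nM, most likely again reported only as a limit.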

Compound 4, half-maximal inhibitory concentration: > 200000 nM
Compound 4: no number, only a limit (the forecaster's own chance of this, stated with the estimate: 80%); the middle value does not contradict the limit.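

Within the data shown here, compound 4 reads > 200000 nM, a limit and not a number, and compound 2 is likewise a limit, so no step between them can be read. The compounds shown leave open whether hydrogen in place of methyl at this place changes the read-out in this assay at all.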